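Working notes: anilide exchange in the growth-inhibition series

The source may report more compounds than this note shows. Statements on the series, on what has been measured and on what is new or still open speak of the compounds shown alone.

Measured so far in a functional assay on ACHN cells (Homo sapiens) for cytotoxicity; a lower number here means a stronger inhibitor of growth, a higher number a weaker inhibitor of growth:
- compound 1, `CCCCCCCCC(=O)N1c2ccccc2CC1C(=O)Nc1ccc(C(F)(F)F)cc1`: compound 1 gives 3780 nM
- compound 2, `Cc1ccc(S(=O)(=O)N2c3ccccc3CC2C(=O)Nc2cc(Cl)cc(Cl)c2)cc1`: compound 2 reaches only a limit, > 10000 nM
- compound 3, `CC(NC(=O)OC(C)(C)C)C(=O)N1c2ccccc2CC1C(=O)Nc1ccc(C(C)(F)F)cc1`: compound 3 gives 6990 nM

Compound 3 stands at the higher of the two numbers given, and its nearest neighbour is compound 1; the gap between the two lies within the scatter, so no order between them can be claimed. Within the data shown here, the only other value, that of compound 2, is a limit and not a number, (the limit of > 10000 nM in this assay, at which 1 of the 3 values shown sits).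

Compound 4, `CC(NC(=O)OC(C)(C)C)C(=O)N1c2ccccc2CC1C(=O)Nc1cc(Cl)cc(Cl)c1`, has not yet been measured. It keeps the acyl group of compound 3 and changes the anilide: 3,5-dichlorophenyl in place of 4-(1,1-difluoroethyl)phenyl on an amide-type nitrogen. Among the measured compounds shown here, no measured pair isolates this change. For the measured compounds named here, the one compound already bearing 3,5-dichlorophenyl on the amide nitrogen is compound 2, which gives only a limit; its acyl group differs as well, so the comparison to compound 3 is not clean.

On this thin basis the expected outcome is a weakening, of a size that may or may not exceed the scatter: the estimated step is a 1.4-fold higher number from compound 3 to compound 4 (0.16 log units; within the scatter). Compound 4 is estimated at 10000 nM, with a range from 3500 nM to 30000 nM, and a real chance that only a limit is returned.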

Compound 4, concentration for 50% growth inhibition: 5040 nM
Estimate against measurement, compound 4: 2.0-fold (0.30 log units) above; the measured number falls inside the stated range.
By their numbers in this assay, from the lowest: compounds 1, 4 and 3 (each within the scatter of the next). At a limit, above all of these: compound 2.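

In this assay, among these compounds, compounds 3 and 4 form the first measured pair that isolates the anilide on the amide-type nitrogen. Exchanging 4-(1,1-difluoroethyl)phenyl for 3,5-dichlorophenyl gives a 1.4-fold lower number from compound 3 to compound 4 (0.14 log units; within the scatter), so the two anilides cannot be told apart when paired with this acyl group. Compound 4 also shows that 3,5-dichlorophenyl on this nitrogen can return a number, which compound 2, with the same anilide and a different acyl group, did not show, as its value is only a limit: the limit of > 10000 nM in this assay, at which 1 of the 4 values shown sits.

This single pair leaves open whether the exchange would stay as small with another acyl group, such as the nonanoyl chain of compound 1, and whether the limit seen for compound 2 comes from its acyl group. As far as these compounds go, it is also open whether the anilide position would respond more clearly to a markedly different substituent, such as a carboxylic acid or an amine on the phenyl ring, since both groups compared here are halogen-bearing phenyl rings.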